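The source may hold more compounds than are shown below. What is called first, only, known or untested is meant among the compounds shown, and "the series" means these compounds.

Of the compounds shown here, three have been measured in a functional assay (Homo sapiens) for inhibition of Nucleic Acid, tested at 100 uM (on this read-out higher numbers stand for more inhibition at the one concentration tested (going by the name of the read-out) and lower numbers for less inhibition), so far. Compound 1, `CN(C)c1nccc2c1ncn2C1O[C@H](CO)[C@@H](O)[C@H]1O`, gives 0% in this assay. Compound 2, `C[C@H]1OC(n2cnc3c(N)nccc32)[C@H](O)[C@@H]1O`, gives 18% in this assay, and compound 3, `Nc1nccc2c1ncn2[C@H]1C[C@H](O)[C@@H](CO)O1`, gives 18% in this assay. Compound 1 thus stands at the bottom of the three numbers: its gap to compound 2 and its gap to compound 3 are each beyond the usual scatter of repeated measurements, while compounds 2 and 3 sit at the same number. Going by the values given here, none of these three pairs differs in a single place, so no step within the measured set can be read directly.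

The next compound, compound 4, `OC[C@H]1OC(n2cnc3c(Cl)nccc32)[C@H](O)[C@@H]1O`, is compared with compound 1. The change is chloro in place of dimethylamino on an aromatic carbon. Among the compounds with values here, since no measured pair carries a comparable change, the size of the step is uncertain. Compound 1 gives the lowest number of the set, and the other two compounds sit higher, so the expectation for compound 4 is a small rise at most, and the step of a number 6 percentage points higher from compound 1 to compound 4 (within the scatter) is expected to lie within the scatter. Compound 4 is therefore estimated to give 6% in this assay, with a range from -10% to 25%.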

Compound 4, a percentage reported as inhibition, at one concentration (the size of the read-out at that concentration, not a potency): 76%
Estimate against measurement, compound 4: 70 percentage points below, outside the stated range (above it).
By their numbers in this assay, from the lowest: compound 1; then compounds 2 and 3 (each within the scatter of the next); then compound 4.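

In this assay, going by these compounds alone, chloro in place of dimethylamino on this aromatic carbon, next to the ring nitrogen, gives a number 76 percentage points higher from compound 1 to compound 4 (beyond the scatter), the first step in the set that can be read at a single place. It shows that this position is far from indifferent in this assay: with the rest of the structure unchanged, exchanging this one group is enough to produce a large step. The change removes three heavy atoms and one hydrogen-bond acceptor and brings in a single chlorine, but no measurement shown here bears on why the number rises so far.

A single pair cannot tell whether the step comes from the presence of chloro or the absence of dimethylamino, and a bromo, methyl or methoxy group on the same carbon would help to separate the two. On these data alone, it also remains open whether the same exchange would give a step of similar size with the other parts of the structure changed, as they are in compound 2 and compound 3.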